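Removing the acid group: what compound 3 may bring back

The source may hold more compounds than are shown below. What is called first, only, known or untested is meant among the compounds shown, and "the series" means these compounds.

Compound 1 `CCCCCCCCCCc1ccc(-c2noc(CN)n2)cc1`: 62%
Compound 2 `CCCCCCCCCCc1ccc(-c2noc(CC[C@@H](N)C(=O)O)n2)cc1`: 5%

In an assay on HeLa cells for inhibition of sphingosine-1-phosphate transporter SPNS2 (Mus musculus), read by LC-MS, tested at 2 uM (on this read-out lower numbers stand for less inhibition and higher numbers for more inhibition at the one concentration tested (going by the name of the read-out)), compound 2 gives the lowest of the two numbers; its nearest neighbour is compound 1, which stands far higher. Compound 3 `CCCCCCCCCCc1ccc(-c2noc(CC(CN)OC(C)=O)n2)cc1` differs from compound 2 by a group of 7 heavy atoms (4 carbon, 1 nitrogen, 2 oxygen; no ring) in place of a group of 6 heavy atoms (3 carbon, 1 nitrogen, 2 oxygen; no ring), on a saturated chain carbon bound to an aromatic carbon. For the measured compounds named here, the one step that bears on this is a number 57 percentage points lower from compound 1 to compound 2 (beyond the scatter), where the 2-amino-2-carboxyethyl group arrived and inhibition fell sharply. Compound 3 gives that group up again while keeping an amine, so a sizeable rise is expected, a number 33 percentage points higher from compound 2 to compound 3 (beyond the scatter), though not fully back to compound 1. Compound 3 is estimated at 38%, between 12% and 64%.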

Compound 3, a percentage reported as inhibition, at one concentration (the size of the read-out at that concentration, not a potency): 0%
For compound 3 the middle estimate is 38 percentage points above the measured one, outside the stated range (below it).
By their numbers in this assay, from the lowest: compounds 3 and 2 (each within the scatter of the next); then compound 1.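

In this assay replacing the 2-amino-2-carboxyethyl group gives a number 5 percentage points lower from compound 2 to compound 3 (within the scatter) and so shows that an amine on this chain, without the carboxylic acid, does not restore the read-out. Against the plain amine, the new group gives a number 62 percentage points lower from compound 1 to compound 3 (beyond the scatter) and joins the 2-amino-2-carboxyethyl group in reading low on a saturated chain carbon bound to an aromatic carbon. No supporting measurement accounts for this result.

Going by these compounds, whether a free hydroxyl in place of the acetyl ester would change the number stays open. So does the result for a two-carbon chain ending in a plain amine.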